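A few compounds are considered here, and "the series" means these few. Any claim that something is new, unique, unknown or untested is made for them only; others in the source may bear on it.

Compound 1, `O=[N+]([O-])C1=Cc2cc(F)ccc2OC1C(F)(F)F`: 1150 nM
Compound 2, `O=[N+]([O-])C1=Cc2cc(C#Cc3ccc(CO)cc3)ccc2OC1C(F)(F)F`: 2000 nM
Compound 3, `O=[N+]([O-])C1=Cc2c(Cl)cccc2OC1C(F)(F)F`: 15700 nM

All three were tested in an assay on 1321N1 cells for antagonist activity at P2Y purinoceptor 6 (Homo sapiens), read by FLIPR and calcium flux; a lower number here means a stronger inhibitor, a higher number a weaker inhibitor. Compound 3 gives the highest number of the three. Its nearest neighbour is compound 2, which sits below it by a gap beyond the usual scatter, and compound 1 sits further below still, again beyond the scatter. Among the compounds with values here, no pair among the three differs in only one place, so no single step between measured compounds can be read off.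

Compound 4, `O=[N+]([O-])C1=Cc2c(I)cccc2OC1C(F)(F)F`, has not yet been measured in this assay. It differs from compound 3 by iodo in place of chloro on an aromatic carbon. Nothing among the three measured compounds shows how such an exchange of one halogen for another moves the number in this assay. The step from compound 3 to compound 4 is therefore expected to be small, within the scatter, a 1.3-fold lower number from compound 3 to compound 4 (0.12 log units; within the scatter), with no firm direction. Compound 4 is expected to give about 12000 nM in this assay, somewhere between 4000 nM and 40000 nM.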

Compound 4, half-maximal inhibitory concentration: 13100 nM
Compound 4: the middle estimate sits 1.1-fold (0.04 log units) below what was measured, within the range that was stated.
By their numbers in this assay, from the lowest: compounds 1 and 2 (each within the scatter of the next); then compounds 4 and 3 (each within the scatter of the next).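

With iodo in place of chloro on this aromatic carbon, this assay shows a 1.2-fold lower number from compound 3 to compound 4 (0.08 log units; within the scatter), the only step shown so far that changes a single place. At this position, then, the exchange of one halogen for the other leaves the number unresolved from the scatter, so the two compounds cannot be told apart by this read-out. No measurement offered here explains this result or bears on what the two halogens do at this carbon.

The compounds shown leave open whether a group that is not a halogen on this carbon, such as an amine or a carboxylic acid, would move the number in this assay. They also leave open whether fluoro or bromo at the same carbon would match chloro and iodo.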